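Swapping the Methyl Ester Chain End for a Nitrile

This account rests on a few compounds, and the source may have more. Where it says the series, first, only, none or still open, it means among the compounds named here.

In a functional assay on PC-3 cells (Homo sapiens) for cytotoxicity, read by colorimetric assay and MTT assay (on this read-out lower numbers stand for stronger inhibition and higher numbers for weaker inhibition), compound 2 `COC(=O)CCn1c(=O)c(-c2ccc(OC)cc2)cc2c(OC)cc(OC)cc21` gives 10000 nM. Its nearest neighbour is compound 1 `COc1ccc(-c2cc3c(OC)cc(OC)cc3n(CC(=O)OCc3ccccc3)c2=O)cc1`, and compound 1 gives 10000 nM, level with it. Among the compounds with values here, the one measured step bearing on the next change shows no change at the digits printed from compound 1 to compound 2 (within the scatter), with (methoxycarbonyl)methyl in place of benzyloxycarbonyl. Compound 3 `COc1ccc(-c2cc3c(OC)cc(OC)cc3n(CCC#N)c2=O)cc1` carries cyano in place of methoxycarbonyl on a saturated chain carbon, two bonds along the chain from an aromatic nitrogen. This single step is thin evidence, but it points to no shift beyond the scatter. The expected step is no change at the digits printed from compound 2 to compound 3 (within the scatter). For compound 3 the estimated value is 10000 nM, with an expected range of 4000 nM to 20000 nM.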

Compound 3, half-maximal inhibitory concentration: 10000 nM
Beside the measured number, compound 3's estimate shows no gap at the digits printed; the range from low to high includes it.
By their numbers in this assay, from the lowest: compounds 1, 2 and 3 (each within the scatter of the next).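

In this assay, cyano in place of methoxycarbonyl gives no change at the digits printed from compound 2 to compound 3 (within the scatter), so a nitrile end on this chain reads the same as a methyl ester end. Cyanomethyl in place of benzyloxycarbonyl likewise gives no change at the digits printed from compound 1 to compound 3 (within the scatter), which puts a chain end without the benzyl ester level with one that carries it. Nothing available offers a reason for this flat reading. As far as these compounds go, whether an amine, a carboxylic acid or a longer chain here would move the reading away from compound 3 at 10000 nM stays open. So does the effect of any change on the shared core.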